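The source may report more compounds than this note shows. Statements on the series, on what has been measured and on what is new or still open speak of the compounds shown alone.

Three compounds of the series have been through a functional assay, with a stated time of 30 min (on this read-out higher numbers stand for weaker inhibition and lower numbers for stronger inhibition), and none has returned a number. Compound 1 `Oc1ccc(/C=N/c2ccc(OCc3ccccc3)cc2)c(O)c1` gives > 200000 nM in this assay, which is a limit of the assay and not a measured value. Compound 3 `COc1ccc(/C=N/c2ccc(OCc3ccccc3)cc2)c(O)c1` gives > 200000 nM in this assay, again a limit. Compound 2 `O=[N+]([O-])c1ccc(O)c(/C=N/c2ccc(OCc3ccccc3)cc2)c1` gives > 200000 nM in this assay, also a limit. Going by the values given here, the only single-point step available, a step that the two limits leave unreadable from compound 1 to compound 3, is unreadable because the limit of > 200000 nM in this assay, at which 3 of the 3 values shown sit, leaves both its ends without a number. Among the compounds with values here, compound 2 thus stands at the limit alongside the two other measured compounds, and no measured step gives it a numerical footing in this assay.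

Compound 4 `Oc1ccc(F)cc1/C=N/c1ccc(OCc2ccccc2)cc1` differs from compound 2 by fluoro in place of nitro on an aromatic carbon. Within the data shown here, no measured step bears on this change: the sole step recorded concerns a different part of the shared core and is itself unreadable. With every measured compound at the limit, nothing shown points to compound 4 leaving it. Compound 4 is therefore estimated at 300000 nM, with a range from 150000 nM to 1000000 nM, in this assay. The expected step that the limit leaves unreadable from compound 2 to compound 4 is, on that estimate, not readable beyond the limit.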

Compound 4, half-maximal inhibitory concentration: > 200000 nM
Compound 4 was reported as a limit; the forecaster's own chance of this, stated with the estimate: 80%; the middle value does not contradict the limit.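

Compound 4 adds no readable step against compound 2 or compound 1, because each pair has a limit at both ends, not a number: the limit of > 200000 nM in this assay, at which 4 of the 4 values shown sit. The compounds shown leave open whether any change on the shared core gives measurable inhibition, and how large the effect of fluoro in place of nitro is.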